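The source may report more compounds than this note shows. Statements on the series, on what has been measured and on what is new or still open speak of the compounds shown alone.

Three compounds were measured in a functional assay on WM 266-4 cells (Homo sapiens) for antiproliferative activity, read by MTT assay, with a stated time of 24 h; a higher number here means a weaker inhibitor of growth, a lower number a stronger inhibitor of growth:

compound 1, `COc1ccc(C2=NN(C(=O)c3cncc(Br)c3)C(c3ccc(Cl)cc3)C2)cc1`, gives 1290 nM
compound 2, `COc1ccc(C2=NN(C(=O)c3ccc(Cl)nc3)C(c3ccc(Cl)cc3)C2)cc1`, gives 1450 nM
compound 3, `COc1ccc(C2=NN(C(=O)c3cncc(Br)c3)C(c3ccc(OCc4ccccc4)cc3)C2)cc1`, gives 6240 nM

Compound 1 and compound 2 differ only at one place, (6-chloropyridin-3-yl in place of 5-bromopyridin-3-yl on a carbonyl carbon), and the measured step is a 1.1-fold higher number from compound 1 to compound 2 (0.05 log units; within the scatter). Compound 3 differs from compound 1 elsewhere, (benzyloxy in place of chloro on an aromatic carbon), and that step is a 4.8-fold higher number from compound 1 to compound 3 (0.68 log units; beyond the scatter), so compound 3 gives the highest number of the three.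

Compound 4, `COc1ccc(C2=NN(C(=O)c3ccc(Cl)nc3)C(c3ccc(OCc4ccccc4)cc3)C2)cc1`, has not been measured. It carries the core of compound 3 together with the same change already seen from compound 1 to compound 2: 6-chloropyridin-3-yl in place of 5-bromopyridin-3-yl on a carbonyl carbon. Within the data shown here, because the step of a 1.1-fold higher number from compound 1 to compound 2 (0.05 log units; within the scatter) stayed within the scatter, the same change on the core of compound 3 is expected to give a step of about a 1.1-fold higher number from compound 3 to compound 4 (0.04 log units; within the scatter) in this assay, with the remaining uncertainty resting on only one earlier example of this change. Compound 4 is therefore estimated at 6900 nM, with a likely range from 3200 nM to 15000 nM.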

Compound 4, concentration for 50% growth inhibition: 10600 nM
Compound 4: middle estimate off by 1.5-fold (0.19 log units), on the low side, and the stated range covers the measured number.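

In this assay, replacing 5-bromopyridin-3-yl with 6-chloropyridin-3-yl on the carbonyl carbon gives a 1.7-fold higher number from compound 3 to compound 4 (0.23 log units; within the scatter), and the two instances of this change agree: the same change on two cores in this assay, a 1.1-fold higher number (0.05 log units; within the scatter) from compound 1 to compound 2 and a 1.7-fold higher number (0.23 log units; within the scatter) from compound 3 to compound 4, 1.5-fold (0.18 log units) apart, within the scatter of two such steps.
Benzyloxy in place of chloro on an aromatic carbon gives a 7.3-fold higher number from compound 2 to compound 4 (0.86 log units; beyond the scatter), and this change also carries over from one core to the other without a difference beyond the scatter: the same change on two cores in this assay, a 4.8-fold higher number (0.68 log units; beyond the scatter) from compound 1 to compound 3 and a 7.3-fold higher number (0.86 log units; beyond the scatter) from compound 2 to compound 4, 1.5-fold (0.18 log units) apart, within the scatter of two such steps.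
Among these four compounds, each change therefore behaves alike on both cores, but each comparison rests on only two cores, the pyridine change stays within the scatter on both, and none of this shows that either change would carry over to other cores in the series.

The compounds shown leave open how an amine or a carboxylic acid on that aromatic carbon would compare with chloro and benzyloxy. They also leave open how a pyridin-3-yl without a halogen would compare on the carbonyl carbon.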